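Valine to lysine side chain in a purine glycinamide series

This account rests on a few compounds, and the source may have more. Where it says the series, first, only, none or still open, it means among the compounds named here.

Compound 1 `CC(C)[C@H](NC(=O)CN(c1nc(Cl)nc2[nH]cnc12)C1CC1)C(=O)OCc1ccccc1` carries an isopropyl side chain on the amino-ester portion of the shared core. In a functional assay on the whole organism (Tail, strain ICR) with Mus musculus as the target, in the tail flick test, with a stated time of 120 min, at a dose of 25 umol/kg by the oral route (a lower number here means a weaker effect, a higher number a stronger effect of the compound at the dose given), compound 1 gives 27.3%, the lower of the two numbers recorded so far. Its proline analogue, compound 2 `O=C(OCc1ccccc1)[C@@H]1CCCN1C(=O)CN(c1nc(Cl)nc2[nH]cnc12)C1CC1`, gives 38.4% in this assay, and the gap between the two lies beyond the scatter of repeated measurements. Going by the values given here, no single-change step between measured compounds is available, so the effect of altering the side chain at this position has to be judged from compound 1 alone.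

Compound 3 `NCCCC[C@H](NC(=O)CN(c1nc(Cl)nc2[nH]cnc12)C1CC1)C(=O)OCc1ccccc1` differs from compound 1 in one place: 4-aminobutyl in place of isopropyl on a saturated chain carbon bound to an amide-type nitrogen and a carbonyl carbon. For this assay a modest step in the upward direction from compound 1 to compound 3 is expected, of the order of a number 4.7 percentage points higher from compound 1 to compound 3 (within the scatter), though a change within the scatter would be just as consistent with what is known. On that basis compound 3 is estimated to give 32%, with a plausible range from 10% to 55%.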

Compound 3, a percentage reported as activity, at one dose (the size of the read-out at that dose, not a potency): 16.8%
For compound 3 the middle estimate is 15.2 percentage points above the measured one, within the range that was stated.
By their numbers in this assay, from the lowest: compound 3; then compound 1; then compound 2.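

Going by these compounds alone, replacing isopropyl with 4-aminobutyl on a saturated chain carbon bound to an amide-type nitrogen and a carbonyl carbon gives the first reading of a single change at this position, and the reading in this assay is a number 10.5 percentage points lower from compound 1 to compound 3 (beyond the scatter) for this pair. Within the data shown here, the position is thus not indifferent to its side chain, and this particular change moves the number downward, something no pair among the earlier compounds could show. Nothing measured here bears on why the number falls.

From the compounds shown here alone, what stays open is whether the fall belongs to the amine at the end of 4-aminobutyl or to the greater length of the chain, since the change from compound 1 to compound 3 alters both at once. A plain butyl chain at this position would separate the two, while a shorter chain ending in an amine or one ending in a carboxylic acid would show how far the result depends on the chain length and on the end group.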